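Swapping dichlorophenyl for bromophenyl in a very potent set

The compounds below may be only part of what the source reports. "The series", "measured", "known", "first", "only" and "open" are said of these compounds alone.

Compound 1 `NC1=NC2(CCSCC2)N(OCCCOc2ccc(Cl)c(Cl)c2)C(N)=N1` – 1 nM
Compound 2 `NC1=NC2(CCOCC2)N(OCCCOc2cccc(Cl)c2Cl)C(N)=N1` – 5 nM
Compound 3 `NC1=NC2(CCSCC2)N(OCCCOc2cc(Cl)c(Cl)cc2Cl)C(N)=N1` – 1 nM

In a functional assay on HCT-116 cells (Homo sapiens) for antiproliferative activity, read by MTT assay, with a stated time of 72 h (on this read-out higher numbers stand for weaker inhibition and lower numbers for stronger inhibition), compound 2 at 5 nM has the highest of the three numbers, which makes it the weakest so far. Compound 4 `NC1=NC2(CCOCC2)N(OCCCOc2cccc(Br)c2)C(N)=N1` keeps the core of compound 2 but carries 3-bromophenyl in place of 2,3-dichlorophenyl on an oxygen on a saturated carbon. Among the compounds with values here, no measured step tests bromine. The nearest guide, on a different core, is chloro in place of hydrogen on an aromatic carbon, which shows no change at the digits printed from compound 1 to compound 3 (within the scatter) in size. Going by that one step, no change beyond the scatter is expected in this assay for this swap. The estimated step is no change at the digits printed from compound 2 to compound 4 (within the scatter) with no favoured direction. Compound 4 is expected at about 5 nM (1.5 nM to 20 nM).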

Compound 4, half-maximal inhibitory concentration: 40 nM
The estimate for compound 4 lay 8.0-fold (0.90 log units) below the measured number; measured number outside the range, above it.
By their numbers in this assay, from the lowest: compounds 1 and 3 (each within the scatter of the next); then compound 2; then compound 4.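

In this assay the aryl group on an oxygen on a saturated carbon proves sensitive to change: 3-bromophenyl in place of 2,3-dichlorophenyl gives an 8.0-fold higher number from compound 2 to compound 4 (0.90 log units; beyond the scatter) on this core. The earlier chloro step on the other core had stayed within the scatter, so not every change to this ring leaves the number in place. This swap alters both the kind and the count of halogen at once, and no measured evidence explains the rise.

3-Chlorophenyl on the core of compound 2 could separate those two changes. On these data alone, whether the swap has a similar effect on the core of compound 1 also remains open.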